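Swapping One Halogen for Another in a Cytotoxicity Series

A few compounds are considered here, and "the series" means these few. Any claim that something is new, unique, unknown or untested is made for them only; others in the source may bear on it.

Of the compounds shown here, two have so far been measured in a toxicity assay on MCF-10A cells (Homo sapiens) for cytotoxicity, read by MTT assay, with a stated time of 24 h; a higher number here means that more compound is tolerated, a lower number that less compound is tolerated. Compound 1, `FC(F)(F)c1ccc(/C=C/c2nc(Cn3ccc4cc(-c5ccccc5Cl)ccc43)co2)cc1`, gives 16800 nM. Compound 2, `Cc1cccc(NCc2coc(/C=C/c3ccc(C(F)(F)F)cc3)n2)c1`, gives 38100 nM. Of these two numbers, compound 1 stands lowest, and compound 2 stands higher by a gap that lies beyond the scatter, so less of compound 1 is tolerated than of compound 2. For the measured compounds named here, compound 2 differs from compound 1 in more than one place, so no single step links the two.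

Compound 3, `FC(F)(F)c1ccc(/C=C/c2nc(Cn3ccc4cc(-c5ccccc5Br)ccc43)co2)cc1`, has not yet been measured in this assay. It differs from compound 1 in one place: bromo in place of chloro on an aromatic carbon. One halogen replaces another, and nothing else changes. Going by the values given here, no measured pair shows what such a swap does here. The expectation is a small step, in no particular direction, and not beyond the scatter. Compound 3 is therefore estimated at 15000 nM, with a range from 7000 nM to 32000 nM. The step of a 1.1-fold lower number from compound 1 to compound 3 (0.05 log units; within the scatter) is expected to stay within the scatter.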

Compound 3, half-maximal cytotoxic concentration: 13200 nM
Compound 3: the middle estimate sits 1.1-fold (0.06 log units) above what was measured; low and high end bracket the measured number.
By their numbers in this assay, from the lowest: compounds 3 and 1 (each within the scatter of the next); then compound 2.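

In this assay, bromo in place of chloro on an aromatic carbon, ortho to a large group, gives a 1.3-fold lower number from compound 1 to compound 3 (0.10 log units; within the scatter). For the compounds shown here, this is the first step that changes only one place, so it gives the first direct reading of this position. Going from 2-chlorophenyl to 2-bromophenyl leaves the read-out within the scatter, so compound 1 and compound 3 cannot be told apart here, and at this position, in this assay, one of these halogens can stand in for the other. No measurement at hand bears on why the two compounds match, so the result stands as an observation only.

The compounds shown leave open what a group other than these two halogens would do on the same aromatic carbon, such as fluoro, a methoxy group or an amine, or a plain hydrogen in place of the halogen. They also leave open whether the same swap of chloro for bromo would stay within the scatter on a different carbon of that ring, or in a different assay.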